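Cytotoxicity of Compound 4 after a Carbonyl-for-Sulfonyl Swap

This account rests on a few compounds, and the source may have more. Where it says the series, first, only, none or still open, it means among the compounds named here.

Of the compounds shown here, three sharing one core have been tested in an ADME assay on HEK293 cells (Homo sapiens) for cytotoxicity, read by MTT assay, with a stated time of 48 h; a higher number here means a weaker inhibitor, a lower number a stronger inhibitor. Compound 1 `COc1ccc(-c2cn3cc(C4=CCN(S(=O)(=O)CCc5ccccc5)CC4)ccc3n2)cc1OC` gives 70300 nM. Compound 2 `COc1ccc(-c2cn3cc(C4=CCN(C(=O)C5CCCCC5)CC4)ccc3n2)cc1OC`, which carries cyclohexylcarbonyl in place of phenethylsulfonyl on the ring nitrogen, gives 72100 nM. Compound 3 `COc1ccc(-c2cn3cc(C4=CCN(S(=O)(=O)C5CCCC5)CC4)ccc3n2)cc1OC`, with cyclopentylsulfonyl on that nitrogen, gives 103000 nM. Compound 3 holds the highest of the three numbers, yet every step that separates it from the others lies within the scatter: a 1.5-fold higher number from compound 1 to compound 3 (0.17 log units; within the scatter) and a 1.4-fold higher number from compound 2 to compound 3 (0.15 log units; within the scatter). The three compounds therefore cannot be told apart on this assay.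

Compound 4 `COc1ccc(-c2cn3cc(C4=CCN(C(=O)c5cccs5)CC4)ccc3n2)cc1OC` is not yet measured. It changes the group on the ring nitrogen again: (thiophen-2-yl)carbonyl in place of cyclopentylsulfonyl on an amine nitrogen in a ring. Among the compounds with values here, the steps that bear on this change are the swap of a sulfonyl for a carbonyl group seen in a 1.0-fold higher number from compound 1 to compound 2 (0.01 log units; within the scatter) and the reverse swap seen in a 1.4-fold higher number from compound 2 to compound 3 (0.15 log units; within the scatter); both stayed within the scatter. Compound 4 is therefore expected to stay close to compound 3, with a step of about a 1.3-fold lower number from compound 3 to compound 4 (0.11 log units; within the scatter) and no movement beyond the scatter in either direction. The estimated value for compound 4 in this assay is 80000 nM, within a range from 40000 nM to 160000 nM.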

Compound 4, half-maximal inhibitory concentration: 98100 nM
Estimate against measurement, compound 4: 1.2-fold (0.09 log units) below, and the stated range covers the measured number.
By their numbers in this assay, from the lowest: compounds 1, 2, 4 and 3 (each within the scatter of the next).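

The new result extends what can be placed on this amine nitrogen in a ring: (thiophen-2-yl)carbonyl in place of cyclopentylsulfonyl gives a 1.0-fold lower number from compound 3 to compound 4 (0.02 log units; within the scatter) in this assay and so changes both the linking group and the ring it carries without a readable effect. The comparison with a single change, thiophen-2-yl in place of cyclohexyl on a carbonyl carbon, gives a 1.4-fold higher number from compound 2 to compound 4 (0.13 log units; within the scatter) and adds a five-membered aromatic ring with 1 hetero atom to the carbonyl series, while the comparison with the phenethylsulfonyl compound gives a 1.4-fold higher number from compound 1 to compound 4 (0.14 log units; within the scatter) and also stays within the range that repeat measurements alone could produce. All four groups shown, whether joined through a sulfonyl or a carbonyl, therefore cannot be told apart in this assay, and nothing measured here offers an explanation for that.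

The compounds shown leave open whether a carboxylic acid, or an amine carried on a longer chain, on this same nitrogen would move the number beyond the scatter. They also leave open whether a change elsewhere on the shared core would do so.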